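Tolerance Across Three Aryl Variants of a Shared Core

The source may report more compounds than this note shows. Statements on the series, on what has been measured and on what is new or still open speak of the compounds shown alone.

Measured so far in this study:
compound 1 `COc1cc(-c2nnc(SCc3ccc(Cl)cc3)o2)ccc1O` with 480000 nM
compound 2 `COc1cc(-c2nnc(SCc3ccccc3Br)o2)ccc1O` with 363000 nM

In an ADME assay on cells (Mus musculus, strain BALB/c) for cytotoxicity, read by MTT assay, with a stated time of 24 h (a lower number here means that less compound is tolerated, a higher number that more compound is tolerated), compound 1 gives 480000 nM, and compound 2 gives 363000 nM. Going by the values given here, the single measured step, a 1.3-fold lower number from compound 1 to compound 2 (0.12 log units; within the scatter), stays within the scatter, so the two numbers cannot be ordered. Among the compounds with values here, compound 2 holds the lower of the two numbers, with compound 1 its only neighbour.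

Compound 3 `COc1cccc(CSc2nnc(-c3ccc(O)c(OC)c3)o2)c1` differs from compound 2 by 3-methoxyphenyl in place of 2-bromophenyl on a saturated chain carbon bound to a sulfur. Within the data shown here, the only step that bears on it, the step from compound 1 to compound 2 at the same position, stayed within the scatter, so compound 3 is expected to show no step beyond the scatter, a 1.1-fold higher number from compound 2 to compound 3 (0.04 log units; within the scatter). Compound 3 is estimated at 400000 nM, expected between 200000 nM and 800000 nM.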

Compound 3, half-maximal cytotoxic concentration: 389000 nM
The estimate for compound 3 lay 1.0-fold (0.01 log units) above the measured number; measured number inside the range.
By their numbers in this assay, from the lowest: compounds 2, 3 and 1 (each within the scatter of the next).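

In this assay, at the saturated chain carbon bound to a sulfur, the comparison now reaches beyond the two halogen-bearing aryl groups: the data show a 1.1-fold higher number from compound 2 to compound 3 (0.03 log units; within the scatter) and a 1.2-fold lower number from compound 1 to compound 3 (0.09 log units; within the scatter). The 3-methoxyphenyl group, with 1 hydrogen-bond acceptor where 2-bromophenyl has 0, thus gives a number within the scatter of both earlier compounds. Nothing available explains this result. The compounds shown leave open whether a carboxylic acid, an amine or a longer chain at this place would give a step beyond the scatter.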